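Benzyl to phenyl on the amine of a nitropyrimidine series

The compounds below may be only part of what the source reports. "The series", "measured", "known", "first", "only" and "open" are said of these compounds alone.

Measured compounds:
- compound 1 `CCOC(=O)CN(Cc1ccccc1)c1nc(NCc2cccc(OC)c2)ncc1[N+](=O)[O-]`: 57400 nM
- compound 2 `COC(=O)CN(C)c1nc(NCc2ccccc2)ncc1[N+](=O)[O-]`: 85900 nM
- compound 3 `CCOC(=O)CNc1nc(Nc2ccc(Cl)cc2)ncc1[N+](=O)[O-]`: > 100000 nM

The read-out throughout is a functional assay on MCF7 cells (Homo sapiens) for antiproliferative activity, read by MTT assay, with a stated time of 48 h; on this read-out lower numbers stand for stronger inhibition and higher numbers for weaker inhibition. Compound 1 gives 57400 nM in this assay. Compound 2 gives 85900 nM in this assay, the higher of the two numbers reported, and its distance from compound 1 lies within the usual scatter of such measurements, so the two cannot be ranked against each other. For compound 3 the result in this assay is a limit of the assay rather than a number, > 100000 nM; it sits at the limit of > 100000 nM in this assay, at which 1 of the 3 values shown sits. Within the data shown here, no two measured compounds differ in only one place, so no single step can be read off directly.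

Compound 4 `COC(=O)CN(C)c1nc(Nc2ccccc2)ncc1[N+](=O)[O-]` has not yet been measured. It differs from compound 2 as follows: phenyl in place of benzyl on a nitrogen on an aromatic ring. Among the measured compounds shown here, compound 3, which also carries an aryl group directly on the ring nitrogen, gave only a limit, but it differs from compound 2 in more than one place, so its value shows only that an anilino compound of this kind was inactive up to the limit. On that basis compound 4 is expected to be weaker than compound 2, with a step of a 1.7-fold higher number from compound 2 to compound 4 (0.24 log units; within the scatter) in this assay. Compound 4 is estimated at 150000 nM in this assay, expected to fall between 60000 nM and 400000 nM, and a limit is a real possibility.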

Compound 4, half-maximal inhibitory concentration: > 100000 nM
Compound 4 was reported as a limit (the forecaster's own chance of this, stated with the estimate: 55%); the middle value lies beyond the limit too.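

Among these compounds, compound 2 and compound 4 are the first pair here that differ in one place, so the benzylamino to anilino change can now be read on its own in this assay, as an at least 1.1-fold higher number from compound 2 to compound 4 (0.06 log units; that floor lies within the scatter). Compound 4 gives > 100000 nM, which is a limit of the assay, so this floor does not separate compound 4 from compound 2 beyond the usual scatter, and the pair cannot be ranked. What the result adds is that, with the methyl ester and the N-methyl group held as in compound 2, the anilino compound also reaches the limit, which compound 3 alone could not show because it differs from compound 2 in more than one place: the limit of > 100000 nM in this assay, at which 2 of the 4 values shown sit.

As far as these compounds go, how far compound 4 lies past the limit stays unknown, so the true size of the step remains open, and with it whether removing the benzyl carbon matters at all in this assay. Also open, from the compounds shown here alone, is how this position would respond to a longer chain such as phenethyl, or to an aryl ring carrying an amine, and whether a carboxylic acid in place of the ester would alter the picture.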